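The compounds below may be only part of what the source reports. "The series", "measured", "known", "first", "only" and "open" are said of these compounds alone.

Measured compounds in a functional assay on CHO-K1 cells for antagonist activity at C-X-C chemokine receptor type 3 (Homo sapiens), read by FLIPR and calcium flux; on this read-out lower numbers stand for stronger inhibition and higher numbers for weaker inhibition: compound 1 `CC1(C)[C@@H]2CC[C@@]1(CS(=O)(=O)N1CCN(c3ccc(Br)cn3)CC1)C(=O)C2` gives 1580 nM; compound 2 `CC1(C)[C@@H]2CC[C@@]1(CS(=O)(=O)N1CCN(c3cc4ccccc4cn3)CC1)C(=O)C2` gives 15800 nM; compound 3 `CC1(C)[C@@H]2CC[C@@]1(CS(=O)(=O)N1CCN(c3ccc(C(F)(F)F)cn3)CC1)C(F)C2` gives 794 nM.

Compound 3 holds the lowest of the three numbers, but its gap to compound 1 lies within the scatter, so the two cannot be ranked; only compound 2 stands clearly apart, and the step of a 10-fold higher number from compound 1 to compound 2 (1.00 log units; beyond the scatter) shows how far. The unmeasured compound 4 `CC1(C)[C@@H]2CC[C@@]1(CS(=O)(=O)N1CCN(c3ccc(C(F)(F)F)cn3)CC1)C(NS(C)(=O)=O)C2` differs from compound 3 in one place: methanesulfonamido in place of fluoro on a saturated ring carbon. Among the compounds with values here, no measured step touches that ring carbon. Compounds 1 and 3 differ there, but also on the amine nitrogen in the ring, so their two values show only that both lie within the scatter of each other. Within the data shown here, the one measured step, from compound 1 to compound 2, concerns the aryl group on the amine nitrogen and says nothing about the five-membered ring. Among the measured compounds shown here, with no comparable step to lean on, the expected change from compound 3 to compound 4 in this assay is a 1.5-fold higher number from compound 3 to compound 4 (0.18 log units; within the scatter), a step not beyond the scatter in either direction, and compound 4 is estimated at 1200 nM, with a range from 300 nM to 5000 nM.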

Compound 4, half-maximal inhibitory concentration: 631 nM
Compound 4: middle estimate off by 1.9-fold (0.28 log units), on the high side; low and high end bracket the measured number.
By their numbers in this assay, from the lowest: compounds 4, 3 and 1 (each within the scatter of the next, the first and the last beyond it); then compound 2.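

In this assay, within the data shown here, the change at this saturated ring carbon gives a 1.3-fold lower number from compound 3 to compound 4 (0.10 log units; within the scatter), the first direct reading of a replacement at this position with everything else held constant. Methanesulfonamido brings more heavy atoms than fluoro, along with a hydrogen-bond donor and hydrogen-bond acceptors, yet the assay cannot separate compound 4 from compound 3, so this one exchange on the five-membered ring leaves the number within the scatter. No evidence is available to explain this result.

On these data alone, it remains open whether an amine, a carboxylic acid or a longer chain on this carbon would also stay within the scatter of compound 3. As far as these compounds go, it is also open whether methanesulfonamido would give the same outcome with 5-bromopyridin-2-yl, rather than the trifluoromethyl-bearing aryl group, on the amine nitrogen in the ring.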